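Series notes: the step from compound 3 to compound 4

The compounds below may be only part of what the source reports. "The series", "measured", "known", "first", "only" and "open" are said of these compounds alone.

In an ADME assay on microsomes from liver (Rattus norvegicus) for metabolic stability, read by LC-MS, using NADPH, with a stated time of 30 min, tested at 0.1 uM, in the presence of a further agent that is not named here (on this read-out lower numbers stand for a less stable compound and higher numbers for a more stable compound), compound 3 (`Nc1ncc(-c2ccc(C(=O)O)cc2)nc1-c1ccc(C(F)(F)F)cc1`) gives > 90%, which is a limit and not a number. Compound 1 (`Nc1ncc(-c2ccc(C(=O)N3CCC(O)C3)cc2)nc1-c1ccc(C(F)(F)F)cc1`) gives > 90%, also a limit. Compound 2 (`Nc1ncc(-c2ccc(C(=O)N3CC[C@@H](O)C3)cc2)nc1-c1ccc(C(F)(F)F)cc1`) gives > 90%, again a limit. Compound 3 therefore has no numeric reference point in the series, and what stands is the limit of > 90% in this assay, at which 3 of the 3 values shown sit.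

Compound 4 (`Nc1ncc(-c2ccc(C(=O)N3CCC(O)CC3)cc2)nc1-c1ccc(C(F)(F)F)cc1`) carries 4-hydroxypiperidin-1-yl in place of hydroxy on a carbonyl carbon.

The nearest measured steps are a step that the two limits leave unreadable from compound 1 to compound 3 and a step that the two limits leave unreadable from compound 2 to compound 3. Both exchange hydroxy and 3-hydroxypyrrolidin-1-yl on a carbonyl carbon. A third is a step that the two limits leave unreadable from compound 1 to compound 2, where the only difference is the fact that one of compounds 1 and 2 is drawn with a defined configuration and the other without, at the place where they differ. No size can be carried over from a step that the two limits leave unreadable from compound 1 to compound 3, so no step beyond the scatter is expected in this assay, although any shift would more likely be downward, given the ceiling. The expected step is a number no higher from compound 3 to compound 4 (the limit leaves the size open). For compound 4 the estimate is 90%, with an expected range of 74% to 99%.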

Compound 4, percent of the compound remaining: > 90%
Compound 4: a limit, no number; the forecaster's own chance of this, stated with the estimate: 55%; the middle value lies on the limit itself.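

In this assay compound 4 gives > 90%, which is a limit and not a number. Among the compounds shown here, no step can therefore be read between compound 4 and compound 1, compound 2 or compound 3. The compounds shown leave open whether these four differ at all on this read-out: the limit of > 90% in this assay, at which 4 of the 4 values shown sit.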